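The source may report more compounds than this note shows. Statements on the series, on what has been measured and on what is new or still open speak of the compounds shown alone.

Measured so far in an ADME assay on Vero cells (Chlorocebus sabaeus) for cytotoxicity, read by MTT assay, with a stated time of 72 h; on this read-out lower numbers stand for higher toxicity in this test and higher numbers for lower toxicity in this test:

Compound 1, `O[C@@H]1Cc2cc(F)ccc2N[C@H](c2ccccc2)C1`: > 300000 nM, a limit of the assay rather than a number.
Compound 2, `O[C@@H]1Cc2ccccc2N[C@H](c2ccc(Cl)cc2)C1`: > 300000 nM, likewise a limit of the assay.
Compound 3, `O[C@@H]1Cc2cc(Cl)ccc2N[C@H](c2ccc(Cl)cc2)C1`: 76600 nM.

Compound 3 is thus the only one of the three that gives a number in this assay; the other two sit at the limit. The change leading to compound 4, `O[C@@H]1Cc2cc(F)ccc2N[C@H](c2ccc(Cl)cc2)C1`, is fluoro in place of chloro on an aromatic carbon. Going by the values given here, the one measured step that bears on it is an at least 3.9-fold lower number from compound 2 to compound 3 (0.59 log units; beyond the scatter), where putting a chloro onto the shared core in place of hydrogen pulled the number down from the limit of > 300000 nM in this assay, at which 2 of the 3 values shown sit, to a measurable value. Compound 4 carries a fluoro at that position instead, and compound 1, which also carries a fluoro there, sits at the limit. Compound 4 is therefore expected to land between the limit and the number of compound 3, as a 2.0-fold higher number from compound 3 to compound 4 (0.29 log units; within the scatter), with the estimate for compound 4 being 150000 nM in a range from 60000 nM to 300000 nM.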

Compound 4, half-maximal cytotoxic concentration: 194000 nM
Compound 4: middle estimate off by 1.3-fold (0.11 log units), on the low side, within the range that was stated.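

In this assay, the kind of halogen at this place on the shared core matters, not just the presence of one: fluoro in place of chloro gives a 2.5-fold higher number from compound 3 to compound 4 (0.40 log units; beyond the scatter). Fluoro therefore does not reproduce the number seen with chloro, although compound 4 still gives a measured value rather than a limit. Fluoro in place of hydrogen gives an at least 1.5-fold lower number from compound 2 to compound 4 (0.18 log units; that floor lies within the scatter) and chloro in place of hydrogen gives an at least 1.5-fold lower number from compound 1 to compound 4 (0.18 log units; that floor lies within the scatter) on the core of compound 1, and the chloro-for-hydrogen change can only be set side by side on two cores: the same change on two cores in this assay, an at least 3.9-fold lower number (0.59 log units; beyond the scatter) from compound 2 to compound 3 and an at least 1.5-fold lower number (0.18 log units; that floor lies within the scatter) from compound 1 to compound 4; the limit leaves it open whether they differ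

As far as these compounds go, compound 2, with hydrogen at this place, gives only a limit, and how far it truly lies from compound 4 stays open. Also open, from the compounds shown here alone, is where other groups at this place, such as a methyl, a methoxy or a nitrile, would fall relative to chloro and fluoro.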